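Sulfonate esters with a shared core: notes toward compound 4

The compounds below may be only part of what the source reports. "The series", "measured", "known", "first", "only" and "open" are said of these compounds alone.

Measured so far in a functional assay on HT-29 cells (Homo sapiens) for antiproliferative activity, read by sulforhodamine B assay, with a stated time of 48 h; a higher number here means a weaker inhibitor, a lower number a stronger inhibitor:
- compound 1, `CC(C)C(=O)Nc1cccc(S(=O)(=O)Oc2ccccc2C(C)C)c1`: 16000 nM
- compound 2, `CCCC(=O)Nc1ccc(S(=O)(=O)Oc2ccccc2C(C)C)cc1`: 4900 nM
- compound 3, `CCCC(=O)Nc1ccc(S(=O)(=O)Oc2ccccc2I)cc1`: 11000 nM

Compound 2 gives the lowest number of the three in this assay. Its nearest neighbour is compound 3, and the step of a 2.2-fold higher number from compound 2 to compound 3 (0.35 log units; beyond the scatter) is beyond the scatter. For the measured compounds named here, compound 1 sits further off, and compound 1 and compound 2 differ in more than one place, so the two values show only that compound 1 is the weaker of the pair.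

The unmeasured compound 4, `CC(C)c1ccccc1OS(=O)(=O)c1ccc(NC(=O)NCC2CCCC2)cc1`, departs from compound 2 at the amide end: (cyclopentylmethyl)amino in place of propyl on a carbonyl carbon. Cut one bond further out, the change reads propylcarbonyl to (cyclopentylmethyl)carbamoyl.

Going by the values given here, the single measured step, a 2.2-fold higher number from compound 2 to compound 3 (0.35 log units; beyond the scatter), concerns the aromatic carbon bearing isopropyl or iodo, not the carbonyl carbon, so no measured step bears directly on the change from compound 2 to compound 4. Without a precedent at the amide end, the expected step is one of no clear direction and of modest size, a 1.0-fold higher number from compound 2 to compound 4 (0.01 log units; within the scatter), with a wide margin on either side.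

Compound 4 is therefore estimated at 5000 nM, within a range from 1500 nM to 20000 nM.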

Compound 4, half-maximal inhibitory concentration: 6800 nM
Beside the measured number, compound 4's estimate is 1.4-fold (0.13 log units) below it; measured number inside the range.
By their numbers in this assay, from the lowest: compounds 2, 4, 3 and 1 (each within the scatter of the next, the first and the last beyond it).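

At the carbonyl carbon of the amide end, the first measured change gives a 1.4-fold higher number from compound 2 to compound 4 (0.14 log units; within the scatter) in this assay, so compound 2 and compound 4 are not separated by this read-out. This change brings in (cyclopentylmethyl)amino, with more heavy atoms than propyl, a five-membered non-aromatic ring of carbon only and a hydrogen-bond donor, and the step still stays within the scatter. The earlier compounds shown here offered no step at this place, and the only one available, a 2.2-fold higher number from compound 2 to compound 3 (0.35 log units; beyond the scatter), concerned the aromatic carbon bearing isopropyl or iodo. Nothing measured here offers an account of the result at the amide end.

The single step changes the ring, the chain length and the nitrogen together, so the compounds shown do not separate their contributions: a simple ethylamino, an open-chain hexylamino or a cyclohexylmethylamino group on the same carbonyl carbon would each bear on that. They also leave open whether a more distinct change at this carbon, such as a chain ending in a carboxylic acid or a tertiary amine, would move the number beyond the scatter, and whether iodo and (cyclopentylmethyl)amino would behave the same in one molecule.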